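A few compounds are considered here, and "the series" means these few. Any claim that something is new, unique, unknown or untested is made for them only; others in the source may bear on it.

Measured compounds in a functional assay on A-431 cells (Homo sapiens) for cytotoxicity, read by MTT assay, with a stated time of 72 h, tested at 1 uM; a lower number here means less inhibition of growth, a higher number more inhibition of growth at the concentration tested:

compound 1 `Cc1ccnc(/C(N)=N/NC(=S)N2CCOCC2)c1` gives 33.6%
compound 2 `Cc1ccnc(/C(N)=N/NC(=S)N2CCSCC2)c1` gives 34.6%
compound 3 `N/C(=N\NC(=S)N1CCSCC1)c1ccc(F)cn1` gives 48.7%

Compound 3 stands highest of the three; the gaps to compound 2 and to compound 1 are beyond the scatter, while compound 2 and compound 1 sit within the scatter of each other. The difference between the core of compound 3 and the core of compound 2 is not broken down here.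

One change is measured: morpholin-4-yl in place of thiomorpholin-4-yl on a thiocarbonyl carbon, with the step of a number 1 percentage points lower from compound 2 to compound 1 (within the scatter). Compound 4 `N/C(=N\NC(=S)N1CCOCC1)c1ccc(F)cn1` carries the same change on the core of compound 3: morpholin-4-yl in place of thiomorpholin-4-yl on a thiocarbonyl carbon.

Going by the values given here, from the single measured step it is expected that compound 4 stays close to compound 3, with an estimated step of a number 1.7 percentage points lower from compound 3 to compound 4 (within the scatter). Compound 4 is estimated at 47% in this assay, with a range of 36% to 58%, resting on one step only.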

Compound 4, percent growth inhibition at one concentration: 31.8%
Compound 4: the middle estimate sits 15.2 percentage points above what was measured; the measured number lies below the stated range.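

In this assay, morpholin-4-yl in place of thiomorpholin-4-yl on a thiocarbonyl carbon gives a number 16.9 percentage points lower from compound 3 to compound 4 (beyond the scatter), and the change does not carry over with the same size from one core to the other: the same change on two cores in this assay, a number 1 percentage points lower (within the scatter) from compound 2 to compound 1 and a number 16.9 percentage points lower (beyond the scatter) from compound 3 to compound 4, 15.9 percentage points apart, beyond the scatter of two such steps

On these two pairs, the size of the step depends on the core, so a step read on one core is a poor guide to the other. Two pairs do not show which part of the difference between the cores matters, and they set no rule for any further core.

Still open, on these data alone, is how a piperidin-1-yl group or a dimethylamino group on the thiocarbonyl carbon would compare on each core. Also open, as far as these compounds go, is whether the step stays as large with a chlorine in place of the fluorine of compound 3.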